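Halogenated phenyl rings on the aromatic nitrogen

This account rests on a few compounds, and the source may have more. Where it says the series, first, only, none or still open, it means among the compounds named here.

Compound 2 `N#CC1=C(N)Oc2c(N)cc3nc4ccccc4nc3c2C12C(=O)N(Cc1cnnn1-c1c(F)cccc1F)c1ccccc12` carries a 2,6-difluorophenyl on an aromatic nitrogen. In a functional assay on HepG2 cells (Homo sapiens) for antiproliferative activity, read by MTT assay, with a stated time of 48 h (a higher number here means a weaker inhibitor, a lower number a stronger inhibitor), compound 2 reaches only a limit of the assay, > 50000 nM. Going by the values given here, its neighbour compound 1 `CCc1ccccc1-n1nncc1CN1C(=O)C2(C(C#N)=C(N)Oc3c(N)cc4nc5ccccc5nc4c32)c2ccccc21`, with 2-ethylphenyl at the same place, gives 17900 nM in this assay, and the step of an at least 2.7-fold higher number from compound 1 to compound 2 (0.44 log units; beyond the scatter) is the only measured step that bears on this position; its stated size follows from the limit of > 50000 nM in this assay, at which 1 of the 2 values shown sits. Compound 3 `N#CC1=C(N)Oc2c(N)cc3nc4ccccc4nc3c2C12C(=O)N(Cc1cnnn1-c1ccc(Cl)cc1Cl)c1ccccc12` differs from compound 2 by 2,4-dichlorophenyl in place of 2,6-difluorophenyl on an aromatic nitrogen. Among the compounds with values here, no measured step shows what a 2,4-dichlorophenyl does here; the one step shows only that a halogenated phenyl in place of 2-ethylphenyl weakened inhibition. Compound 3 is therefore expected to stay weak, with an expected step of an at least 1.1-fold lower number from compound 2 to compound 3 (0.04 log units; that floor lies within the scatter) that need not exceed the scatter. The estimate for compound 3 is 45000 nM, ranging from 15000 nM to 150000 nM.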

Compound 3, half-maximal inhibitory concentration: > 50000 nM
Compound 3: a limit, no number; the forecaster's own chance of this, stated with the estimate: 55%; middle value at least 1.1-fold (0.04 log units) from the limit.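

In this assay compound 3 also gives only a limit, > 50000 nM. Putting 2,4-dichlorophenyl in place of 2-ethylphenyl on the aromatic nitrogen also weakens inhibition, with an at least 2.7-fold higher number from compound 1 to compound 3 (0.44 log units; beyond the scatter), so the loss no longer rests on compound 2 alone and holds for two different halogenated phenyl rings. The step between these two halogenated compounds cannot be read, since both stop at the same limit: the limit of > 50000 nM in this assay, at which 2 of the 3 values shown sit.

On these data alone, whether 2,4-dichlorophenyl and 2,6-difluorophenyl differ at all at this position remains open, as does whether the halogens themselves or the loss of the ethyl group accounts for the weakening. As far as these compounds go, how an unsubstituted phenyl, or a phenyl carrying an amine, a carboxylic acid or a longer chain, would behave here also remains open.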